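Trading a dimethylphenyl for a chlorophenyl arm

This account rests on a few compounds, and the source may have more. Where it says the series, first, only, none or still open, it means among the compounds named here.

Three compounds share one core and differ only in the group attached to the carbonyl. Compound 1 `Cc1ccc(CC(C)C(=O)N2CCN(c3ccc(C(F)(F)F)cc3[C@@H](N)CC(C)C)CC2)cc1C` gives 240 nM in an assay on HEK293 cells for displacement of a labelled ligand from Melanocortin receptor 4 (Homo sapiens); a lower number here means a stronger inhibitor, a higher number a weaker inhibitor. Compound 2 `Cc1cc(CC(C)C(=O)N2CCN(c3ccc(C(F)(F)F)cc3[C@@H](N)CC(C)C)CC2)ccc1Cl` gives 71 nM in this assay, and compound 3 `CC(C)C[C@H](N)c1cc(C(F)(F)F)ccc1N1CCN(C(=O)COc2ccc3ccccc3c2)CC1` gives 2000 nM in this assay. Compound 1 therefore sits second highest of the three numbers: compound 2 lies nearest, and compound 3 furthest away.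

Compound 4 `CC(C)C[C@H](N)c1cc(C(F)(F)F)ccc1N1CCN(C(=O)C(C)Cc2ccc(Cl)cc2)CC1` is the unmeasured variant. It differs from compound 1 in one place: 4-chlorophenyl in place of 3,4-dimethylphenyl on a saturated chain carbon, two bonds along the chain from a carbonyl carbon Cut one bond further out, the change reads 1-(3,4-dimethylbenzyl)ethyl to 1-(4-chlorobenzyl)ethyl.

The most relevant measured step is a 3.4-fold lower number from compound 1 to compound 2 (0.53 log units; beyond the scatter), where a chloro replaces one methyl on the aromatic carbon. For the measured compounds named here, compound 4 carries that chloro but lacks the remaining methyl, and no measured pair isolates that second loss. The steps of an 8.3-fold higher number from compound 1 to compound 3 (0.92 log units; beyond the scatter) and a 28-fold higher number from compound 2 to compound 3 (1.45 log units; beyond the scatter) concern a quite different group on the carbonyl and bear little on this change. A modest move toward a lower number in this assay is expected, partly tempered by the missing methyl.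

Compound 4 is estimated at 130 nM, within 50 nM to 350 nM, an expected step of a 1.8-fold lower number from compound 1 to compound 4 (0.27 log units; within the scatter).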

Compound 4, inhibition constant: 47 nM
Compound 4: middle estimate off by 2.8-fold (0.44 log units), on the high side; the whole stated range lies above it.
By their numbers in this assay, from the lowest: compounds 4 and 2 (each within the scatter of the next); then compound 1; then compound 3.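

In this assay the methyl that compound 2 keeps on its ring can go, with hydrogen in its place, and the result is a 1.5-fold lower number from compound 2 to compound 4 (0.18 log units; within the scatter) and so no readable difference between the two compounds. For the compounds shown here, the earlier compounds could not show this, since their only step on this ring swapped one methyl for chloro and left the other in place. The full exchange of 3,4-dimethylphenyl for 4-chlorophenyl therefore gives a 5.1-fold lower number from compound 1 to compound 4 (0.71 log units; beyond the scatter) even with the second methyl gone, and the large gap of a 43-fold lower number from compound 3 to compound 4 (1.63 log units; beyond the scatter) shows that the 1-(4-chlorobenzyl)ethyl group also keeps the number far lower than ((naphthalen-2-yl)oxy)methyl does on the same carbonyl carbon.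

Nothing available here gives a reason for any of these steps. Still open, going by these compounds, is how much the chloro itself contributes, which a plain unsubstituted phenyl would help to answer, and whether fluoro, bromo or methoxy in its place on the ring would hold the number at this level.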